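Piperidine sulfonamide series: freeing the pyrrolidine amide

The compounds below may be only part of what the source reports. "The series", "measured", "known", "first", "only" and "open" are said of these compounds alone.

Measured so far in an assay on U2OS cells for inhibition of secreted frizzled-related protein 1 (Homo sapiens), read by a luciferase reporter, with a stated time of 18 h; on this read-out higher numbers stand for an effect only at larger amounts of compound and lower numbers for an effect already at smaller amounts:
compound 1 `CN(C)c1ccc(C(=O)N2CCC(NS(=O)(=O)c3cc(S(=O)(=O)c4ccccc4)ccc3C(F)(F)F)CC2)cn1` gives 70 nM
compound 2 `O=C(O)c1cccc(S(=O)(=O)N2CCC(NS(=O)(=O)c3cc(S(=O)(=O)c4ccccc4)ccc3C(F)(F)F)CC2)c1` gives 190 nM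
compound 3 `CC(C)(C)OC(=O)N1CCC[C@@H]1C(=O)N1CCC(NS(=O)(=O)c2cc(S(=O)(=O)c3ccccc3)ccc2C(F)(F)F)CC1` gives 210 nM

Compound 3 shows the highest number of the three. Its gap to compound 2 lies within the scatter, so no order between them can be read. Compound 1 stands apart: a 3.0-fold higher number from compound 1 to compound 3 (0.48 log units; beyond the scatter), and a 2.7-fold higher number from compound 1 to compound 2 (0.43 log units; beyond the scatter). Both measured steps vary the group on the ring nitrogen of the shared core, and both move away from compound 1 by a modest amount.

Compound 4 `O=C([C@H]1CCNC1)N1CCC(NS(=O)(=O)c2cc(S(=O)(=O)c3ccccc3)ccc2C(F)(F)F)CC1` differs from compound 3 in one place: pyrrolidin-3-yl in place of 1-(tert-butoxycarbonyl)pyrrolidin-2-yl on a carbonyl carbon. Neither measured step covers this change; the nearest relevant information is that the step from compound 1 to compound 3 introduced the group that now shrinks, and that two quite different groups at this position gave numbers within the scatter of each other. The change in this assay is therefore expected to be small, in either direction, with a 1.1-fold lower number from compound 3 to compound 4 (0.02 log units; within the scatter) as the working estimate. Compound 4 is expected to give about 200 nM, with a range from 70 nM to 600 nM.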

Compound 4, half-maximal effective concentration: 700 nM
For compound 4 the middle estimate is 3.5-fold (0.54 log units) below the measured one; the measured number lies above the stated range.
By their numbers in this assay, from the lowest: compound 1; then compounds 2 and 3 (each within the scatter of the next); then compound 4.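

In this assay, this position on the carbonyl carbon proves sensitive after all: replacing 1-(tert-butoxycarbonyl)pyrrolidin-2-yl with pyrrolidin-3-yl gives a clear loss (a 3.3-fold higher number from compound 3 to compound 4 (0.52 log units; beyond the scatter)). The same group also falls behind the other two groups on the ring nitrogen of the shared core (a 3.7-fold higher number from compound 2 to compound 4 (0.57 log units; beyond the scatter); a 10-fold higher number from compound 1 to compound 4 (1.00 log units; beyond the scatter)), so compound 4 has the highest number of the four. The change removes the tert-butoxycarbonyl group, moves the attachment from the 2-yl to the 3-yl position and brings in a hydrogen-bond donor, and no measurement at hand separates these changes or accounts for the loss.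

Which of these changes carries the step remains open. A pyrrolidin-2-yl with a free ring amine, or a pyrrolidin-3-yl carrying tert-butoxycarbonyl on its ring nitrogen, would separate them.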